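From methyl to ethyl on a saturated chain

The source may hold more compounds than are shown below. What is called first, only, known or untested is meant among the compounds shown, and "the series" means these compounds.

Three compounds have values in a physicochemical assay for lipophilicity, read by HPLC, in phosphate buffer, measured as octanol-water partition, at pH 5.5 (on this read-out higher numbers stand for higher lipophilicity and lower numbers for lower lipophilicity), so far:
compound 1 `Nc1cc(OCCNc2ccnc3cc(Cl)ccc23)nc(N)n1` at -0.3
compound 2 `CC(COc1cc(N)nc(N)n1)Nc1ccnc2cc(Cl)ccc12` at -1.34
compound 3 `Nc1cc(OCCCNc2ccnc3cc(Cl)ccc23)nc(N)n1` at -0.08

Compound 2 at -1.34 is the lowest of the three in this assay and lies beyond the usual scatter from both of the others. Compound 4 `CCC(COc1cc(N)nc(N)n1)Nc1ccnc2cc(Cl)ccc12` differs from compound 2 by a single change methyl in place of hydrogen on a saturated chain carbon, two bonds along the chain from a nitrogen on an aromatic ring that puts methyl in place of hydrogen on a saturated chain carbon, two bonds along the chain from a nitrogen on an aromatic ring, so that methyl becomes ethyl.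

The closest measured evidence is a number 1.04 log units lower from compound 1 to compound 2 (beyond the scatter) for methyl in place of hydrogen on a saturated chain carbon bound to a nitrogen on an aromatic ring. That step is large, but it is the only one of its kind and it concerns a different chain carbon. Compound 1 at -0.3 and compound 3 at -0.08 lie within the scatter of each other and add little guidance. No repeat of the large fall is therefore assumed, and no change beyond the scatter is expected in this assay, with the direction left open. The estimated step is a number 0.04 log units higher from compound 2 to compound 4 (within the scatter) and its uncertainty is wide. For compound 4 the estimated value is -1.3 with an expected range from -2 to -0.6 in this assay.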

Compound 4, distribution coefficient: 1.07
The estimate for compound 4 lay 2.37 log units below the measured number, outside the stated range (above it).
By their numbers in this assay, from the lowest: compound 2; then compounds 1 and 3 (each within the scatter of the next); then compound 4.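

In this assay, the carbon two bonds along the chain from a nitrogen on an aromatic ring proved highly sensitive to a small change: methyl in place of hydrogen there gives a number 2.41 log units higher from compound 2 to compound 4 (beyond the scatter) and so turns methyl into ethyl. This large rise runs against the earlier step, a number 1.04 log units lower from compound 1 to compound 2 (beyond the scatter), so the two chain substituents move the number in opposite directions, which the first three compounds could not show. The ethyl group also carries the number past the hydrogen compound, with a number 1.37 log units higher from compound 1 to compound 4 (beyond the scatter), even though ethyl differs from methyl by only 1 carbon. Nothing among the available measurements accounts for this reversal.

The compounds shown leave open whether the upward trend from methyl to ethyl would continue with a longer chain such as propyl, or whether it would survive a branched group such as isopropyl or a hydroxymethyl group on the same carbon. Among these compounds, they also leave open whether the same reversal would appear with the three-carbon chain of compound 3 , since this single series offers no second example.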